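Diacylhydrazine agonists: swapping the aryl group on the amide carbonyl

A few compounds are considered here, and "the series" means these few. Any claim that something is new, unique, unknown or untested is made for them only; others in the source may bear on it.

Compound 1 `CC(C)(C)N(NC(=O)c1ccccc1)C(=O)c1ccccc1F`: 309 nM
Compound 2 `Cc1ccccc1C(=O)N(NC(=O)c1ccccc1)C(C)(C)C`: 224 nM
Compound 3 `Cc1ccccc1C(=O)NN(C(=O)c1ccccc1Cl)C(C)(C)C`: 72.4 nM

The three measured compounds share a common core and were tested in an assay on cells for agonist activity at ecdysone receptor (Bombyx mori), read by a luciferase reporter, with a stated time of 24 h; on this read-out higher numbers stand for an effect only at larger amounts of compound and lower numbers for an effect already at smaller amounts. Compound 3 gives the lowest number of the three; compound 2 sits at a step of a 1.4-fold lower number from compound 1 to compound 2 (0.14 log units; within the scatter) apart from compound 1, and both stand well above compound 3 in that read-out, beyond the usual scatter.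

Compound 4 `CC(C)(C)N(NC(=O)c1ccc(F)cc1)C(=O)c1ccccc1Cl` differs from compound 3 by 4-fluorophenyl in place of 2-methylphenyl on a carbonyl carbon. Within the data shown here, the only measured step that touches a related exchange is the one from compound 1 to compound 2, a step of a 1.4-fold lower number from compound 1 to compound 2 (0.14 log units; within the scatter), but there the methyl and fluoro swap took place on the other carbonyl's aryl ring, so it bears on the present change only loosely. Among the measured compounds shown here, with no closer precedent, a step of a 1.1-fold lower number from compound 3 to compound 4 (0.05 log units; within the scatter) is expected, essentially within the scatter of this assay. Compound 4 is therefore estimated at 65 nM, with a range from 20 nM to 200 nM.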

Compound 4, half-maximal effective concentration: 389 nM
For compound 4 the middle estimate is 6.0-fold (0.78 log units) below the measured one; the whole stated range lies below it.
By their numbers in this assay, from the lowest: compound 3; then compounds 2, 1 and 4 (each within the scatter of the next).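

In this assay, this carbonyl carbon, whose other neighbour is an amide-type nitrogen, does not tolerate every aryl exchange equally: a 5.4-fold higher number from compound 3 to compound 4 (0.73 log units; beyond the scatter) is beyond the scatter, whereas a 1.4-fold lower number from compound 1 to compound 2 (0.14 log units; within the scatter), on the other carbonyl's aryl ring, stayed within it. The 2-methylphenyl and 4-fluorophenyl groups have the same count of heavy atoms and neither has hydrogen-bond donors or acceptors, so those counts do not separate the two compounds, although their numbers differ clearly. No measured evidence accounts for this step.

The compounds shown leave open whether the higher number follows from losing the methyl, from gaining the fluoro, or from where the group sits on the ring. From the compounds shown here alone, how an amine or a carboxylic acid on the aryl ring at this carbonyl carbon would read also remains open.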